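The source may hold more compounds than are shown below. What is called first, only, known or untested is meant among the compounds shown, and "the series" means these compounds.

Of the compounds shown here, three from this series have been measured in a functional assay on PBMC cells (Homo sapiens) for inhibition; a lower number here means a stronger inhibitor, a higher number a weaker inhibitor. Compound 1 `CCC[C@H](N)C(=O)NS(=O)(=O)OC[C@H]1O[C@@H](n2cnc3c(N)ncnc32)[C@H](O)[C@@H]1O` gives 4700 nM. Compound 2 `CC(C)C[C@H](N)C(=O)NS(=O)(=O)OC[C@H]1OC[C@@H](n2cnc3c(N)ncnc32)[C@H](O)[C@@H]1O` gives 1000 nM. Compound 3 `CSCC[C@H](N)C(=O)NS(=O)(=O)OC[C@H]1OC[C@@H](n2cnc3c(N)ncnc32)C[C@@H]1O` gives 5500 nM, the highest of the three numbers; its gap to compound 1 lies within the scatter, whereas compound 2 sits beyond the scatter at a lower number. Compound 4 `Nc1ncnc2c1ncn2[C@@H]1CO[C@H](COS(=O)(=O)NC(=O)[C@@H]2CCCN2)[C@@H](O)C1` differs from compound 3 in one place: pyrrolidin-2-yl in place of 1-amino-3-(methylsulfanyl)propyl on a carbonyl carbon. Among the measured compounds shown here, no pair of measured compounds shares this change, so its effect must be judged from the structural change alone. The step is expected to be small, with no clear direction beyond the scatter, a 1.1-fold higher number from compound 3 to compound 4 (0.04 log units; within the scatter). Compound 4 is therefore estimated at 6000 nM in this assay, within a range from 1500 nM to 25000 nM.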

Compound 4, half-maximal inhibitory concentration: 2800 nM
The estimate for compound 4 lay 2.1-fold (0.33 log units) above the measured number; the measured number falls inside the stated range.
By their numbers in this assay, from the lowest: compound 2; then compounds 4, 1 and 3 (each within the scatter of the next).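

In this assay, replacing 1-amino-3-(methylsulfanyl)propyl with pyrrolidin-2-yl on a carbonyl carbon gives a 2.0-fold lower number from compound 3 to compound 4 (0.29 log units; within the scatter). This shows that, on this core, the position tolerates the open sulfur-bearing chain giving way to a five-membered non-aromatic ring, with no difference that stands clear of the scatter. Nothing measured here offers an explanation for this result. As far as these compounds go, whether a piperidin-2-yl ring or a longer chain ending in an amine on this carbonyl carbon would give a step beyond the scatter remains open.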